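This account rests on a few compounds, and the source may have more. Where it says the series, first, only, none or still open, it means among the compounds named here.

Compound 1 `CC(C)c1ccc(Nc2ccc3c(OCCCN4CCN(C)CC4)cccc3n2)cc1`: 5440 nM
Compound 2 `CN1CCN(CCCOc2cccc3nc(Nc4cc(Cl)cc(Cl)c4)ccc23)CC1`: 1840 nM

Going by the values given here, in a functional assay on NCI-H460 cells (Homo sapiens) for inhibition, read by sulforhodamine B assay, with a stated time of 48 h (on this read-out higher numbers stand for weaker inhibition of growth and lower numbers for stronger inhibition of growth), compound 1 gives the highest of the two numbers; the only other number is lower, a step that is a 3.0-fold lower number from compound 1 to compound 2 (0.47 log units; beyond the scatter). Compound 3 `CN1CCN(CCCOc2cccc3nc(Nc4cccc(Cl)c4)ccc23)CC1` is not yet measured. It differs from compound 1 in one place: 3-chlorophenyl in place of 4-isopropylphenyl on a nitrogen on an aromatic ring. Among the compounds with values here, the only measured step that bears on this exchange is the one to compound 2, where a related change lowered the number beyond the scatter; compound 3 carries one chlorine rather than two, so a smaller move of the same kind in this assay is expected. Compound 3 is estimated at 3000 nM, with a range from 1200 nM to 7500 nM. The expected step is a 1.8-fold lower number from compound 1 to compound 3 (0.26 log units; within the scatter).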

Compound 3, concentration for 50% growth inhibition: 1870 nM
Estimate against measurement, compound 3: 1.6-fold (0.21 log units) above, within the range that was stated.
By their numbers in this assay, from the lowest: compounds 2 and 3 (each within the scatter of the next); then compound 1.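

In this assay, the step of a 1.0-fold higher number from compound 2 to compound 3 (0.01 log units; within the scatter) shows that taking one chloro off the 3,5-dichlorophenyl group leaves the number unchanged within the scatter. The step of a 2.9-fold lower number from compound 1 to compound 3 (0.46 log units; beyond the scatter) shows that a single chloro on the phenyl ring is enough to give the lower number seen for 3,5-dichlorophenyl in place of 4-isopropylphenyl.

Going by these compounds, whether a methoxy or a nitrile in the place of this chloro would give a similar number remains open. No measurement shown here explains the steps.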